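The compounds below may be only part of what the source reports. "The series", "measured", "known", "first", "only" and "open" are said of these compounds alone.

Four closely related compounds are compared here, all sharing one core. Compound 1 `COc1ccc2[nH]c(-c3cn(-c4ccccc4)nc3-c3ccccc3)nc2c1` is measured in a functional assay on HeLa cells (Homo sapiens) for antiproliferative activity, read by MTT assay, with a stated time of 48 h (a higher number here means a weaker inhibitor, a lower number a stronger inhibitor), and gives 2870 nM. Compound 2 `FC(F)(F)c1ccc2[nH]c(-c3cn(-c4ccccc4)nc3-c3ccccc3)nc2c1` differs from compound 1 by trifluoromethyl in place of methoxy on an aromatic carbon; in this assay compound 2 gives 1920 nM, so the change made a 1.5-fold lower number from compound 1 to compound 2 (0.17 log units; within the scatter). Compound 3 `COc1ccc2[nH]c(-c3cn(-c4ccccc4)nc3-c3ccc(Cl)cc3)nc2c1` differs from compound 1 in the core, by chloro in place of hydrogen on an aromatic carbon; in this assay compound 3 gives 3630 nM, a change of a 1.3-fold higher number from compound 1 to compound 3 (0.10 log units; within the scatter). Compound 4 `FC(F)(F)c1ccc2[nH]c(-c3cn(-c4ccccc4)nc3-c3ccc(Cl)cc3)nc2c1` has not yet been measured. It differs from compound 3 by trifluoromethyl in place of methoxy on an aromatic carbon, and this is the same change, at the same place on the core, as that made between the first two compounds. The earlier change stayed within the scatter of repeated measurements, so only a small effect is expected here as well. The expected step is a 1.5-fold lower number from compound 3 to compound 4 (0.18 log units; within the scatter), because the same change earlier gave a 1.5-fold lower number from compound 1 to compound 2 (0.17 log units; within the scatter). Compound 4 is therefore estimated at 2400 nM in this assay, with a plausible range from 1200 nM to 4800 nM.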

Compound 4, half-maximal inhibitory concentration: 4420 nM
Compound 4: the middle estimate sits 1.8-fold (0.27 log units) below what was measured, within the range that was stated.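

In this assay, putting trifluoromethyl in place of methoxy on the core that carries chloro gives a 1.2-fold higher number from compound 3 to compound 4 (0.09 log units; within the scatter), and this step cannot be told apart from the same swap on the core of compound 1: the same change on two cores in this assay, a 1.5-fold lower number (0.17 log units; within the scatter) from compound 1 to compound 2 and a 1.2-fold higher number (0.09 log units; within the scatter) from compound 3 to compound 4, 1.8-fold (0.26 log units) apart, within the scatter of two such steps

Chloro in place of hydrogen gives a 2.3-fold higher number from compound 2 to compound 4 (0.36 log units; beyond the scatter), the only step here beyond the scatter, yet it also cannot be told apart from its earlier counterpart: the same change on two cores in this assay, a 1.3-fold higher number (0.10 log units; within the scatter) from compound 1 to compound 3 and a 2.3-fold higher number (0.36 log units; beyond the scatter) from compound 2 to compound 4, 1.8-fold (0.26 log units) apart, within the scatter of two such steps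

Both changes therefore look transferable between these two cores, but each rests on just one pair of steps, so this does not show that either change has a real, repeatable effect or that it would carry over to any other core.

The compounds shown leave open whether a quite different group in place of methoxy, such as an amine or a carboxylic acid, would shift the number by more than these small steps. They also leave open whether the steps would look the same in another cell line.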